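The compounds below may be only part of what the source reports. "The series", "measured", "known", "first", "only" and "open" are said of these compounds alone.

Measured so far in a physicochemical assay for solubility, at pH 6.8; on this read-out lower numbers stand for lower solubility and higher numbers for higher solubility:
- compound 1 `CN1CCc2nc(C(=O)NC3CNCCC3NC(=O)c3cc4cc(Cl)ccc4[nH]3)sc2C1` gives 996 ug/mL
- compound 2 `CN1CCc2nc(C(=O)NC3CCNCC3NC(=O)c3cc4cc(Cl)ccc4[nH]3)sc2C1` gives 830 ug/mL

Compound 2, at 830 ug/mL, and compound 1, at 996 ug/mL, lie within the scatter of each other, so the two numbers place them at a single level in this assay and nothing separates them.

The next compound to be tested is compound 3 `CCOC(=O)N1CCC(NC(=O)c2nc3c(s2)CN(C)CC3)C(NC(=O)c2cc3cc(Cl)ccc3[nH]2)C1`, which shares the core of compound 2 and differs from it in one place. Ethoxycarbonyl stands in place of hydrogen on an amine nitrogen in a ring ethoxycarbonyl in place of hydrogen on an amine nitrogen in a ring and thus replaces a lone hydrogen with a larger group.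

Among the measured compounds shown here, no pair of measured compounds shows a step of this kind, so the expectation rests on the structural change alone and remains uncertain. A downward move beyond the scatter is expected, with the estimated size being a 6.9-fold lower number from compound 2 to compound 3 (0.84 log units; beyond the scatter) in this read-out. The estimated value for compound 3 is 120 ug/mL with an expected range from 25 ug/mL to 450 ug/mL when it is measured.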

Compound 3, solubility: 37 ug/mL
Compound 3: middle estimate off by 3.2-fold (0.51 log units), on the high side, and the stated range covers the measured number.
By their numbers in this assay, from the lowest: compound 3; then compounds 2 and 1 (each within the scatter of the next).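

In this assay, the amine nitrogen in the six-membered non-aromatic ring proves to be a position where a single change matters: ethoxycarbonyl in place of hydrogen gives a 22-fold lower number from compound 2 to compound 3 (1.35 log units; beyond the scatter), a large step. The earlier compounds shown here could not show this, since they offered no step between compounds carrying a changed group on this nitrogen and their two numbers lay within the scatter of each other. The step belongs to the whole exchange of a lone hydrogen for a group of 5 heavy atoms with no net charge, and no supporting measurement is available to explain why the number fell.

The compounds shown leave open whether the size of the step follows from the carbonyl, from the ethyl part or simply from the loss of the hydrogen on the nitrogen, a question that a methyl group, an acetyl group or a longer chain on the same nitrogen could address. As far as these compounds go, it also remains open whether ethoxycarbonyl on the amine nitrogen of compound 1 would give a step of similar size.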